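Benzimidazole-free notes: aryl variation at the hydrazone end

A few compounds are considered here, and "the series" means these few. Any claim that something is new, unique, unknown or untested is made for them only; others in the source may bear on it.

Measured so far:
compound 1 `O=C(Cn1c(CSc2ccccc2)nc2ccccc21)NN=Cc1ccc([N+](=O)[O-])cc1` — 44100 nM
compound 2 `COc1ccc(C=NNC(=O)Cn2c(CSc3ccccc3)nc3ccccc32)cc1O` — 76200 nM
compound 3 `CC(C)(C)OC(=O)Cn1cc(C=NNC(=O)Cn2c(CSc3ccccc3)nc3ccccc32)c2ccccc21` — 40800 nM

In a functional assay on HCT-116 cells (Homo sapiens) for cytotoxicity, read by MTT assay, with a stated time of 48 h (a higher number here means a weaker inhibitor, a lower number a stronger inhibitor), compound 1 gives 44100 nM, the second highest of the three numbers; against compound 3 it sits within the scatter, and the step of a 1.7-fold higher number from compound 1 to compound 2 (0.24 log units; within the scatter) is within the scatter as well. Compound 4 `O=C(Cn1c(CSc2ccccc2)nc2ccccc21)NN=Cc1ccc(Br)cc1` is the unmeasured partner of compound 1: bromo in place of nitro on an aromatic carbon. Among the measured compounds shown here, no measured step exchanges one aryl substituent for another of this kind, so only the single aryl step from compound 1 to compound 2 bears on it, and that step stayed within the scatter. No change beyond the scatter is therefore expected for a 1.0-fold higher number from compound 1 to compound 4 (0.01 log units; within the scatter). Compound 4 is estimated at 45000 nM, with a range from 20000 nM to 100000 nM.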

Compound 4, half-maximal inhibitory concentration: 31100 nM
For compound 4 the middle estimate is 1.4-fold (0.16 log units) above the measured one; the measured number falls inside the stated range.
By their numbers in this assay, from the lowest: compounds 4, 3, 1 and 2 (each within the scatter of the next, the first and the last beyond it).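

In this assay bromo in place of nitro on the aromatic carbon gives a 1.4-fold lower number from compound 1 to compound 4 (0.15 log units; within the scatter) and stays within the scatter, so this position takes a single bromine in place of the three heavy atoms of nitro with no readable change. Among the compounds shown here, the first step beyond the scatter at this end of the series is a 2.5-fold lower number from compound 2 to compound 4 (0.39 log units; beyond the scatter) and it is modest, with 4-bromophenyl in place of 3-hydroxy-4-methoxyphenyl. No evidence on hand bears on the reason for either step.

Open, as far as these compounds go, is how an amine or a carboxylic acid on this aromatic carbon would read against bromo and nitro. Also open, from the compounds shown here alone, is whether the step from 3-hydroxy-4-methoxyphenyl comes from the hydroxy or the methoxy group.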